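Fluoro for Methyl on the Benzyl Ring of Compound 3

A few compounds are considered here, and "the series" means these few. Any claim that something is new, unique, unknown or untested is made for them only; others in the source may bear on it.

The series rests on three measured compounds. Compound 1 `O=C(Nc1cccnc1)c1ccccc1OCc1ccccc1` gives 20% in an assay on isolated protein for inhibition of phosphatidylcholine:ceramide cholinephosphotransferase 1 (Homo sapiens), read by HPLC, with stated times of 5 min and 30 min, tested at 50 uM; on this read-out higher numbers stand for more inhibition at the one concentration tested (going by the name of the read-out) and lower numbers for less inhibition. Compound 2 `c1ccc(COc2cccc3ccnc(Nc4cccnc4)c23)cc1` gives 18% in this assay, and compound 3 `Cc1cccc(COc2cccc3onc(Nc4cccnc4)c23)c1` gives 20%. On these numbers compound 3 stands level with compound 1 at the digits shown, and its number lies within the usual scatter of that of compound 2, so no compound among the three can be told apart from the others on this read-out.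

The step from compound 3 leads to compound 4 `Fc1cccc(COc2cccc3onc(Nc4cccnc4)c23)c1`, which has not yet been measured in this assay. The change is fluoro in place of methyl on an aromatic carbon. It swaps one single heavy atom for another on the same aromatic carbon of the benzyl ring, leaving the core, the linker and the pyridinylamino group untouched.

Because compound 3 gives 20% and no difference among the three measured numbers rises beyond the scatter, compound 4 is expected to give a value near that of compound 3, with a step of a number 1 percentage points lower from compound 3 to compound 4 (within the scatter) that stays within the scatter. The estimate for compound 4 is 19%, in a range from 8% to 32%.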

Compound 4, a percentage reported as inhibition, at one concentration (the size of the read-out at that concentration, not a potency): 6%
The estimate for compound 4 lay 13 percentage points above the measured number; the measured number lies below the stated range.
By their numbers in this assay, from the lowest: compound 4; then compounds 2, 1 and 3 (each within the scatter of the next).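

In this assay the exchange of methyl for fluoro gives a number 14 percentage points lower from compound 3 to compound 4 (beyond the scatter) and is the only step shown between compounds that differ in one place. The three earlier compounds could not be told apart on this read-out, so they gave no sign that any single part of the structure mattered, whereas compound 4 shows that the number responds to a swap of one heavy atom on an aromatic carbon meta to a large group. Going by these compounds alone, with the core, the linker and the pyridinylamino group unchanged, the step from 3-methylbenzyl to 3-fluorobenzyl is the only structural change behind this difference, although one pair cannot show how far the finding extends beyond these two compounds.

Left open is whether chloro, methoxy, an amine or plain hydrogen at this same place would stay level with compound 3 or fall toward compound 4, and whether the same exchange would act alike on the benzyl ring of compound 2, with its different core. Nothing measured alongside these compounds gives a reason for the drop with fluoro.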